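Compound 4 and a Series Held at the Limit

A few compounds are considered here, and "the series" means these few. Any claim that something is new, unique, unknown or untested is made for them only; others in the source may bear on it.

In a functional assay on MCF7 cells (Homo sapiens) for antiproliferative activity, read by MTT assay, with a stated time of 48 h (a higher number here means a weaker inhibitor, a lower number a stronger inhibitor), compound 1 (`CCn1c(C(=O)NCC#N)ccc1C(CC)(CC)c1ccc(OCCC(O)(CC)CC)c(C)c1`) gives > 50000 nM, which is a limit and not a number. Compound 2 (`C#CCCOC(=O)c1ccc(C(CC)(CC)c2ccc(OCCC(O)(CC)CC)c(C)c2)n1CC`) gives > 50000 nM, also a limit. Compound 3 (`CCC(C)C(NC(=O)c1ccc(C(CC)(CC)c2ccc(OCCC(O)(CC)CC)c(C)c2)n1CC)C(=O)OC`) gives > 50000 nM, again a limit. All of the series measured so far stands at the limit of > 50000 nM in this assay, at which 3 of the 3 values shown sit. Compound 4 (`CCOC(=O)CN(C)C(=O)c1ccc(C(CC)(CC)c2ccc(OCCC(O)(CC)CC)c(C)c2)n1CC`) alters the group on a carbonyl carbon: a group of 8 heavy atoms (5 carbon, 1 nitrogen, 2 oxygen; no ring) in place of a group of 10 heavy atoms (7 carbon, 1 nitrogen, 2 oxygen; no ring), on a carbonyl carbon. The measured changes bearing on this are a step that the two limits leave unreadable from compound 1 to compound 2, a step that the two limits leave unreadable from compound 1 to compound 3 and a step that the two limits leave unreadable from compound 2 to compound 3, and none offers a size to carry over. No shift beyond the scatter, in either direction, is therefore expected, and the expected step is a number no higher from compound 3 to compound 4 (the limit leaves the size open). The estimate for compound 4 is 50000 nM, with an expected range of 20000 nM to 100000 nM.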

Compound 4, half-maximal inhibitory concentration: 3210 nM
Compound 4: the middle estimate sits 16-fold (1.19 log units) above what was measured, outside the stated range (below it).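

Within the data shown here, at this carbonyl carbon, ((ethoxycarbonyl)methyl)(methyl)amino gives the only number in this assay, so the group at this place can move the read-out clear of the limit. The change brings an at least 15-fold lower number from compound 3 to compound 4 (1.19 log units; beyond the scatter) and, measured against the other two groups, an at least 15-fold lower number from compound 2 to compound 4 (1.19 log units; beyond the scatter) and an at least 15-fold lower number from compound 1 to compound 4 (1.19 log units; beyond the scatter) at this same place. The steps among compound 1, compound 2 and compound 3 cannot be read, and those compounds remain limits: the limit of > 50000 nM in this assay, at which 3 of the 4 values shown sit.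

Open, going by these compounds, is whether the methyl on the nitrogen or the ethoxycarbonyl end carries the gain. Also open, on these data alone, is how a carboxylic acid in place of that ethyl ester, or a longer chain, would read.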